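This account rests on a few compounds, and the source may have more. Where it says the series, first, only, none or still open, it means among the compounds named here.

Working notes on the series. Within the data shown here, in a functional assay on CHO cells for antagonist activity at Orexin/Hypocretin receptor type 1 (Homo sapiens), read by FLIPR and calcium flux (on this read-out lower numbers stand for stronger inhibition and higher numbers for weaker inhibition), compound 1 `Cc1cccc(NC(=O)CSc2nnc(-c3ccoc3C)n2Cc2ccco2)c1` gives 2510 nM, the highest of the two numbers so far; its nearest neighbour is compound 2 `Cc1occc1-c1nnc(SCC(=O)Nc2cccc(Cl)c2)n1Cc1ccco1`, which in this assay gives 2000 nM. Among the measured compounds shown here, the only measured step, a 1.3-fold lower number from compound 1 to compound 2 (0.10 log units; within the scatter), alters a substituent on the ring attached to the amide nitrogen and does not reach beyond the scatter.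

Compound 3 `Cc1occc1-c1nnc(SCC(N)=O)n1Cc1ccco1` is not yet measured. Its difference from compound 1 is hydrogen in place of 3-methylphenyl on an amide-type nitrogen. For the measured compounds named here, no measured step removes this ring outright, so the step from compound 1 to compound 2 bears on it only by showing that a change on that ring left the number unchanged; it cannot say what removing the whole group does. Loss of the 3-methylphenyl is expected to give a weaker result in this assay, likely beyond the scatter. For compound 3 the estimated value in this assay is 10000 nM, with a range from 3000 nM to 40000 nM, which is expected to amount to a 4.0-fold higher number from compound 1 to compound 3 (0.60 log units; beyond the scatter).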

Compound 3, inhibition constant: > 15800 nM
Compound 3: only a limit was reported; the forecaster's own chance of this, stated with the estimate: 40%; middle value at least 1.5-fold (0.19 log units) away from the limit.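

In this assay the result for compound 3 is a limit and not a number: the limit of > 15800 nM in this assay, at which 1 of the 3 values shown sits.

Removing the ring from the amide-type nitrogen gives an at least 6.2-fold higher number from compound 1 to compound 3 (0.79 log units; beyond the scatter), and the matching removal of 3-chlorophenyl gives an at least 7.9-fold higher number from compound 2 to compound 3 (0.89 log units; beyond the scatter). The earlier step, a 1.3-fold lower number from compound 1 to compound 2 (0.10 log units; within the scatter), changed only a substituent on that ring, whereas these two steps show that replacing the whole ring with hydrogen on this nitrogen moves the number beyond the scatter.

On these data alone, the full size of this loss stays open, as the limit gives only its lower bound. The compounds shown also do not tell whether an aromatic ring is required here, or whether a cyclohexyl ring or an ethyl chain on the same nitrogen would keep the number near that of compound 1.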